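Furan core, amide nitrogen substituent exchange in lipophilicity

The source may report more compounds than this note shows. Statements on the series, on what has been measured and on what is new or still open speak of the compounds shown alone.

Measured so far:
compound 1, `CNC(=O)c1cc(C(=O)N[C@H]2[C@@H]3C[C@H](O)C[C@@H]32)n([C@@H](C)c2cccc(Cl)c2)n1` — 3.7
compound 2, `CNC(=O)c1cc(C(=O)N[C@H]2CC[C@H](OC)CC2)c([C@@H](C)c2ccccc2)o1` — 4.1

In a physicochemical assay for lipophilicity (a higher number here means a more lipophilic compound, a lower number a more polar compound), compound 2 gives 4.1, the higher of the two numbers; compound 1 gives 3.7, which lies below it by more than the usual scatter. Compound 3, `CNC(=O)c1cc(C(=O)N[C@H]2[C@@H]3C[C@@H](O)C[C@@H]32)c([C@@H](C)c2ccccc2)o1`, has not been measured. It differs from compound 2 on the amide-type nitrogen: a group of 7 heavy atoms (6 carbon, 1 oxygen; one three-membered non-aromatic ring of carbon only, one five-membered non-aromatic ring of carbon only) in place of a group of 8 heavy atoms (7 carbon, 1 oxygen; one six-membered non-aromatic ring of carbon only), on an amide-type nitrogen. The group that enters carries one hydrogen-bond donor where the leaving group carries none, and the same entering group is found in compound 1. The step in this assay from compound 2 to compound 3 is therefore expected to be downward and beyond the scatter, about a number 0.90 log units lower from compound 2 to compound 3 (beyond the scatter). Compound 3 is estimated at 3.2, between 2.7 and 3.7.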

Compound 3, distribution coefficient: 2.8
Beside the measured number, compound 3's estimate is 0.40 log units above it; measured number inside the range.
By their numbers in this assay, from the lowest: compound 3; then compound 1; then compound 2.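

In this assay, the amide-type nitrogen of the shared core responds strongly to its substituent: replacing 4-methoxycyclohexyl with the group bearing a three-membered and a five-membered carbon ring, which carries a hydrogen-bond donor, gives a large step, a number 1.30 log units lower from compound 2 to compound 3 (beyond the scatter). Within the data shown here, this is the first comparison here of compounds that differ in one place. No measurement at hand explains the size of this step. From the compounds shown here alone, whether the same exchange gives a similar step on the core of compound 1 remains open. So does what an amine or a carboxylic acid on this nitrogen substituent would give.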